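The source may hold more compounds than are shown below. What is called first, only, known or untested is meant among the compounds shown, and "the series" means these compounds.

Measured so far in a functional assay on HCT-8 cells (Homo sapiens) for antiproliferative activity, read by MTT assay, with a stated time of 48 h; on this read-out lower numbers stand for stronger inhibition and higher numbers for weaker inhibition:
compound 1 `CCNCC(=O)Nc1cc(OC)ccc1C(=O)c1ccc(OC)c2c1OC(C)(C)C=C2` gives 3690 nM
compound 2 `COc1ccc(C(=O)c2ccc(OC)c3c2OC(C)(C)C=C3)c(NC(=O)CN(C)C)c1` gives 1590 nM
compound 3 `C=C(c1ccc(OC)cc1NC(=O)CNCC)c1ccc(OC)c2c1OC(C)(C)C=C2` gives 1380 nM

Compound 1 and compound 2 share one core and differ in a single place: dimethylamino in place of ethylamino on a saturated chain carbon bound to a carbonyl carbon. That change brought a 2.3-fold lower number from compound 1 to compound 2 (0.37 log units; beyond the scatter). Compound 3 is built on another core; the difference between the two cores is not broken down here. Its number and that of compound 2 lie within the usual scatter of each other, while compound 1 stands higher than both.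

Compound 4 `C=C(c1ccc(OC)cc1NC(=O)CN(C)C)c1ccc(OC)c2c1OC(C)(C)C=C2` has not yet been measured. For the measured compounds named here, it differs from compound 3 by dimethylamino in place of ethylamino on a saturated chain carbon bound to a carbonyl carbon, the same change made on the same place as between compound 1 and compound 2, so the earlier step is the only guide. In this assay compound 4 is expected to show a step of similar size, a 2.2-fold lower number from compound 3 to compound 4 (0.35 log units; beyond the scatter), because the same change gave a 2.3-fold lower number from compound 1 to compound 2 (0.37 log units; beyond the scatter). Going by the values given here, with only one precedent the expectation stays loose. The estimate for compound 4 is 620 nM, expected to fall between 300 nM and 1400 nM.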

Compound 4, half-maximal inhibitory concentration: 690 nM
Estimate against measurement, compound 4: 1.1-fold (0.05 log units) below; measured number inside the range.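

In this assay the swap of ethylamino for dimethylamino on the core of compound 3 gave a step (a 2.0-fold lower number from compound 3 to compound 4 (0.30 log units; within the scatter)) that, read alone, is not clearly larger than the differences expected between repeated measurements. Its meaning comes from the comparison with the earlier step, as the change lowered the number by a similar amount on both cores: the same change on two cores in this assay, a 2.3-fold lower number (0.37 log units; beyond the scatter) from compound 1 to compound 2 and a 2.0-fold lower number (0.30 log units; within the scatter) from compound 3 to compound 4, 1.2-fold (0.06 log units) apart, within the scatter of two such steps. This suggests that the change carried over from one core to the other with its size kept, but two cores are a narrow base, and the result neither predicts its effect on a further core nor explains why the numbers move.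

The compounds shown leave open what other groups on the same saturated chain carbon would do, such as diethylamino, pyrrolidine or morpholine. They also leave open whether either amine would give a similar result on a longer chain, where the amine stands further from the carbonyl.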